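This account rests on a few compounds, and the source may have more. Where it says the series, first, only, none or still open, it means among the compounds named here.

Measured compounds and their inhibition of paw edema:

Compound 1 `N#Cc1c(-c2ccc(Cl)cc2)nc(SCC(=O)Nn2c(COc3ccc(Cl)cc3Cl)nc3ccccc3c2=O)[nH]c1=O`: 64.9%
Compound 2 `N#Cc1c(-c2ccc(O)cc2)nc(SCC(=O)Nn2c(COc3ccc(Cl)cc3Cl)nc3ccccc3c2=O)[nH]c1=O`: 68.4%
Compound 3 `O=C(CSc1nc(-c2ccc(Cl)cc2)c(C(=O)O)c(=O)[nH]1)Nn1c(COc2ccc(Cl)cc2Cl)nc2ccccc2c1=O`: 61.4%

All three share one core and were tested in a functional assay on the whole organism (strain albino) for inhibition, with Rattus norvegicus as the target, read by paw edema, with stated times of 1 h and 2 h, at a dose of 100 mg/kg by the oral route; on this read-out higher numbers stand for more inhibition at the one dose given (going by the name of the read-out) and lower numbers for less inhibition. Compound 1 sits between the other two numbers, but the gaps are small: the step of a number 3.5 percentage points higher from compound 1 to compound 2 (within the scatter) and the step of a number 3.5 percentage points lower from compound 1 to compound 3 (within the scatter) both lie within the scatter, so the three compounds cannot be told apart on these numbers.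

Compound 4 `N#Cc1c(-c2ccc(Cl)cc2)nc(SCC(=O)Nn2c(COc3ccc(Cl)cc3Cl)nc3ccccc3c2=O)n(Cc2ccccc2)c1=O` differs from compound 1 in one place: benzyl in place of hydrogen on an aromatic nitrogen. This is a change of a different kind from the two measured steps. Those steps swapped one group for another on an aromatic carbon and left the hydrogen on the ring nitrogen untouched; here that hydrogen itself is replaced, and the core is no longer a ring with a free hydrogen on nitrogen. Going by the values given here, no measured pair bears directly on such a change, and the two steps that are known were both too small to point in any direction.

With nothing to suggest a shift, the expectation for compound 4 is a step of a number 4.9 percentage points lower from compound 1 to compound 4 (within the scatter), no larger than the scatter. Compound 4 is therefore estimated at 60%, with a range from 45% to 75%.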

Compound 4, a percentage reported as inhibition, in the whole organism at one dose (the size of the read-out at that dose, not a potency): 77.2%
Compound 4: middle estimate off by 17.2 percentage points, on the low side; measured number outside the range, above it.
By their numbers in this assay, from the lowest: compounds 3, 1, 2 and 4 (each within the scatter of the next, the first and the last beyond it).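

In this assay, the ring nitrogen that carries a hydrogen in compound 1 proves to be a place where change can register: benzyl there gives a number 12.3 percentage points higher from compound 1 to compound 4 (beyond the scatter) and this is the only step shown that lies beyond the scatter. The hydrogen on this nitrogen is therefore not required for inhibition of paw edema at this one dose, and a benzyl of 7 heavy atoms, with its six-membered aromatic ring of carbon only, is accepted in its place, something the two swaps on aromatic carbons, hydroxy for chloro and carboxy for cyano, could not reveal. Nothing measured here explains why the number rises with this change.

On these data alone, it remains open whether the rise belongs to the benzyl itself or would also come with a methyl, a longer alkyl chain or an aminoethyl group on the same nitrogen. The compounds shown also leave open how benzyl on this nitrogen would behave together with the hydroxy group of compound 2 or the carboxy group of compound 3.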